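From Pyridin-4-yl to Pyridin-3-yl on a Shared Core

A few compounds are considered here, and "the series" means these few. Any claim that something is new, unique, unknown or untested is made for them only; others in the source may bear on it.

Of the compounds shown here, two built on the same core have been measured. Compound 1 `Nc1ccccc1NC(=O)c1ccc(CSC(=S)N2CCc3cc(Cl)ccc32)cc1` carries a 5-chloro-2,3-dihydro-1H-indol-1-yl group on the thiocarbonyl carbon, whereas compound 2 `CN(Cc1ccncc1)C(=S)SCc1ccc(C(=O)Nc2ccccc2N)cc1` carries methyl((pyridin-4-yl)methyl)amino there. In a functional assay on HeLa cells (Homo sapiens) for antiproliferative activity, read by CCK-8 assay, with a stated time of 72 h, tested at 8 uM (a higher number here means a stronger effect of the compound at the concentration tested, a lower number a weaker effect), compound 2 gives 72.7%, the higher of the two numbers shown; compound 1 gives 65.1%. The change from the first to the second is a number 7.6 percentage points higher from compound 1 to compound 2 (within the scatter), so the two compounds cannot be ranked on these data.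

Compound 3 `CN(Cc1cccnc1)C(=S)SCc1ccc(C(=O)Nc2ccccc2N)cc1` has the same atoms as compound 2, joined differently: pyridin-3-yl in place of pyridin-4-yl on a saturated chain carbon bound to an amide-type nitrogen. Among the measured compounds shown here, no measured step touches this part of the molecule; the only step available, a number 7.6 percentage points higher from compound 1 to compound 2 (within the scatter), swaps the whole group on the thiocarbonyl carbon and was itself within the scatter. With nothing pointing in either direction, the expected step is a number 2.7 percentage points lower from compound 2 to compound 3 (within the scatter), that is, no change beyond the scatter. Compound 3 is therefore estimated to give 70% in this assay, with a likely range from 55% to 82%.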

Compound 3, a percentage reported as inhibition, at one concentration (the size of the read-out at that concentration, not a potency): 68.7%
Compound 3: the middle estimate sits 1.3 percentage points above what was measured; the measured number falls inside the stated range.
By their numbers in this assay, from the lowest: compounds 1, 3 and 2 (each within the scatter of the next).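

In this assay, among the compounds shown here, moving from pyridin-4-yl to pyridin-3-yl on a saturated chain carbon bound to an amide-type nitrogen is the first change made within the pyridine group itself, and it stays within the scatter (a number 4 percentage points lower from compound 2 to compound 3 (within the scatter)), so on these data the two arrangements cannot be told apart at this position. The larger exchange on the thiocarbonyl carbon also stays within the scatter when made with the new group (a number 3.6 percentage points higher from compound 1 to compound 3 (within the scatter)), which means that neither pyridine version can be separated from the 5-chloro-2,3-dihydro-1H-indol-1-yl group of compound 1, and no two of the three compounds can be ranked. No supporting measurement is available to explain this result.

The compounds shown leave open whether a pyridin-2-yl group, a plain phenyl ring or a longer chain in place of the methylene link would give a step beyond the scatter. All three numbers also come from a single concentration, so they leave open whether the compounds would still look alike in the size of their effect at other concentrations.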